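Hydrazone aryl swap: bromohydroxyphenyl to fluorophenyl

This account rests on a few compounds, and the source may have more. Where it says the series, first, only, none or still open, it means among the compounds named here.

Compound 1, `Cc1c(C(=O)N/N=C\c2cccc(F)c2)oc2cccc(O)c12`: in a functional assay on PC-3 cells (Homo sapiens) for inhibition (on this read-out lower numbers stand for stronger inhibition and higher numbers for weaker inhibition), compound 1 gives >= 40000 nM, a limit of the assay.
Compound 2, `Cc1c(C(=O)N/N=C\c2ccc(Br)cc2O)oc2cccc(O)c12`: in this assay compound 2 gives 2050 nM.

Compound 2 holds the only number shown in this assay; the other value is a limit. Compound 3, `Cc1c(C(=O)N/N=C\c2ccc(F)cc2)oc2cccc(O)c12`, differs from compound 2 by 4-fluorophenyl in place of 4-bromo-2-hydroxyphenyl on a carbon with a double bond to nitrogen. For the measured compounds named here, the single measured step that bears on this, an at least 19-fold lower number from compound 1 to compound 2 (1.29 log units; beyond the scatter), ran the other way: the ring carrying neither bromine nor hydroxyl sat at the limit (the limit of >= 40000 nM in this assay, at which 1 of the 2 values shown sits). Compound 3 again carries a fluorophenyl with neither group, so a large rise in the number is expected, a 15-fold higher number from compound 2 to compound 3 (1.17 log units; beyond the scatter), with a fair chance of a limit only. Compound 3 is estimated at 30000 nM, ranging from 8000 nM to 80000 nM.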

Compound 3, half-maximal inhibitory concentration: >= 40000 nM
Compound 3: a limit, no number; the forecaster's own chance of this, stated with the estimate: 55%; middle value at least 1.3-fold (0.12 log units) from the limit.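

In this assay, 4-fluorophenyl in place of 4-bromo-2-hydroxyphenyl gives an at least 19-fold higher number from compound 2 to compound 3 (1.29 log units; beyond the scatter), so the loss at this position is not confined to the 3-fluorophenyl of compound 1. Compound 3 gives a limit, as does compound 1, and the step between these two cannot be read, which leaves the two fluorophenyl groups unranked. Limit values now make up most of the series: the limit of >= 40000 nM in this assay, at which 2 of the 3 values shown sit.

No compound shown carries the bromine or the hydroxyl alone, and their separate shares in compound 2 stay open. As far as these compounds go, whether an amine or a carboxylic acid on this ring would give a measurable number also stays open.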